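The compounds below may be only part of what the source reports. "The series", "measured", "known", "first", "only" and "open" are said of these compounds alone.

Measured compounds:
Compound 1, `Cc1cc(Br)c(C(=O)N=C(N)N)cc1S(C)(=O)=O`: 70 nM
Compound 2, `Cc1cc(-c2cc(Cl)cc(Cl)c2)c(S(C)(=O)=O)cc1C(=O)N=C(N)N`: 130 nM

In a functional assay for inhibition of sodium/hydrogen exchanger (Oryctolagus cuniculus) (a lower number here means a stronger inhibitor, a higher number a weaker inhibitor), compound 1 gives 70 nM, while compound 2 gives 130 nM. Of the two numbers shown, compound 2 holds the highest, but the only other value, that of compound 1, stands within the usual scatter of it, so the two compounds cannot be told apart on this assay.

Compound 3, `CCOc1cc(C)c(C(=O)N=C(N)N)cc1S(C)(=O)=O`, is not yet measured. It differs from compound 2 in one place: ethoxy in place of 3,5-dichlorophenyl on an aromatic carbon.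

Among the measured compounds shown here, no measured pair isolates this change, so the expectation rests on the two values alone. Both bear the same core and the same surrounding groups, and their values sit within the scatter of each other. The step from compound 2 to compound 3 is therefore expected to be small, and the estimate a 1.3-fold lower number from compound 2 to compound 3 (0.11 log units; within the scatter) stays inside the scatter in either direction. Compound 3 is accordingly expected to give about 100 nM in this assay, with a range from 35 nM to 300 nM.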

Compound 3, half-maximal inhibitory concentration: 19 nM
For compound 3 the middle estimate is 5.3-fold (0.72 log units) above the measured one; measured number below the stated range.
By their numbers in this assay, from the lowest: compound 3; then compounds 1 and 2 (each within the scatter of the next).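

Before this result, the only two values in this assay lay within the scatter of each other and differed in more than one place, so they said nothing about the group on this aromatic carbon. Placing ethoxy in place of 3,5-dichlorophenyl, ortho to the methylsulfonyl group and meta to the methyl group, gives a 6.8-fold lower number from compound 2 to compound 3 (0.84 log units; beyond the scatter), which shows that this assay responds to the group at this position and that the large aromatic ring is not needed there: a group of 3 heavy atoms with no ring does better than one of 8 heavy atoms with a ring. No available data explain the gain.

This single step changes the size, the ring and the oxygen all at once, so it cannot tell which of these matters. Methoxy, propoxy, a propyl chain, a dimethylamino group or an unsubstituted phenyl ring at the same carbon would be needed to separate them, and the shown compounds leave open how far the trend extends.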